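Swapping the methoxy arm for a chloro arm

The compounds below may be only part of what the source reports. "The series", "measured", "known", "first", "only" and "open" are said of these compounds alone.

Three close analogues share one core and differ only in the outer aromatic ring. Compound 3 `COc1ccc(-c2ccc(C(O)Cc3cc(OC)c(OC)cc3[N+](=O)[O-])cc2)cc1` carries a methoxy on that ring. In an ADME assay on HeLa Rh cells (Homo sapiens) for cytotoxicity, read by microscopy (on this read-out higher numbers stand for lower toxicity in this test and lower numbers for higher toxicity in this test), compound 3 gives > 244000 nM, and this is a limit of the assay rather than a number, the same limit recorded as the limit of > 244000 nM in this assay, at which 1 of the 3 values shown sits. Compound 1 `COc1cc(CC(O)c2ccc(-c3ccc(C(F)(F)F)cc3)cc2)c([N+](=O)[O-])cc1OC` gives 4100 nM in this assay, and compound 2 `COc1cc(CC(O)c2ccc(-c3ccc(C)cc3)cc2)c([N+](=O)[O-])cc1OC` gives 4700 nM. The change a 1.1-fold higher number from compound 1 to compound 2 (0.06 log units; within the scatter) is small. By contrast, an at least 59-fold higher number from compound 1 to compound 3 (1.77 log units; beyond the scatter) and an at least 51-fold higher number from compound 2 to compound 3 (1.71 log units; beyond the scatter) are both large, so compound 3 stands far apart from compounds 1 and 2 on the numbers known, at the gentle end of this test.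

Compound 4 `COc1cc(CC(O)c2ccc(-c3cccc(Cl)c3)cc2)c([N+](=O)[O-])cc1OC` is not yet measured. Its change from compound 3 is 3-chlorophenyl in place of 4-methoxyphenyl on an aromatic carbon. The two large steps above bear on it: both times the methoxy was replaced by another group, the number fell sharply. A chloro group was not among the tested replacements, but the available steps point the same way, so a large step downward is expected, toward the range of compounds 1 and 2, with some room for a milder outcome.

Compound 4 is therefore estimated at 6000 nM, ranging from 1500 nM to 40000 nM. That estimate means an at least 40-fold lower number from compound 3 to compound 4 (1.60 log units; beyond the scatter), expected as a large decrease.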

Compound 4, half-maximal cytotoxic concentration: 5900 nM
The estimate for compound 4 lay 1.0-fold (0.01 log units) above the measured number, and the stated range covers the measured number.
By their numbers in this assay, from the lowest: compounds 1, 2 and 4 (each within the scatter of the next). At a limit, above all of these: compound 3.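

In this assay the swap to 3-chlorophenyl is also a large step (an at least 41-fold lower number from compound 3 to compound 4 (1.61 log units; beyond the scatter)), so a third replacement of the 4-methoxyphenyl group, and the first with its substituent at the 3 rather than the 4 position of the outer ring, also falls far from compound 3. That shift in substituent position leaves no readable mark against the two 4-substituted rings, as both comparisons stay within the scatter (a 1.3-fold higher number from compound 2 to compound 4 (0.10 log units; within the scatter); a 1.4-fold higher number from compound 1 to compound 4 (0.16 log units; within the scatter)), so among these four compounds the 4-methoxyphenyl ring alone stands apart, and none of the four goes against that. Going by these compounds, for compound 3 the value is a limit of the assay and not a number, so the true size of each step from it stays unknown: the limit of > 244000 nM in this assay, at which 1 of the 4 values shown sits.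

The compounds shown leave open whether this gentle reading belongs to the 4-methoxyphenyl group alone or would also appear with a hydroxy group, an ethoxy group or an amine at that place on the ring. Also open, on these data alone, is how 3-methoxyphenyl and 4-chlorophenyl rings would read, a pair that would separate the choice of group from its position on the ring.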